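A few compounds are considered here, and "the series" means these few. Any claim that something is new, unique, unknown or untested is made for them only; others in the source may bear on it.

Compound 3, whose structure is `CC1CCN(c2c(S(=O)(=O)c3cc(F)cc(F)c3)cnc3c(F)cccc23)CC1`, has the lowest number of the three compounds measured in an assay on isolated protein for displacement of a labelled ligand from metabotropic glutamate receptor 5 (Homo sapiens), with a stated time of 60 min, tested at 1 uM; on this read-out higher numbers stand for more inhibition at the one concentration tested (going by the name of the read-out) and lower numbers for less inhibition; in this assay compound 3 gives 9%. Compound 1, `CC1CCN(c2c(S(=O)(=O)c3cc(Cl)cc(Cl)c3)cnc3c(F)cccc23)CC1`, gives 82% in this assay, and compound 2, `CC1CCN(c2c(S(=O)(=O)c3cccc(F)c3)cnc3c(F)cccc23)CC1`, gives 62%. The measured steps all lead downward toward compound 3: the step of a number 73 percentage points lower from compound 1 to compound 3 (beyond the scatter) and the step of a number 53 percentage points lower from compound 2 to compound 3 (beyond the scatter) are both large, while the step of a number 20 percentage points lower from compound 1 to compound 2 (beyond the scatter) is modest.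

Compound 4, `COc1ccc(S(=O)(=O)c2cnc3c(F)cccc3c2N2CCC(C)CC2)cc1`, differs from compound 3 by 4-methoxyphenyl in place of 3,5-difluorophenyl on a sulfonyl sulfur. Among the measured compounds shown here, no measured step tells what a 4-methoxyphenyl group on the sulfonyl sulfur does in this assay. What the data do show is that compound 3, with the 3,5-difluorophenyl group, sits far below both other groups tried on that sulfur, so the change away from 3,5-difluorophenyl is expected to lift the inhibition, though by an unknown amount. The step is therefore estimated as a number 36 percentage points higher from compound 3 to compound 4 (beyond the scatter), an upward move whose size is uncertain. On this basis compound 4 is expected to give about 45% in this assay, with a range from 12% to 80%.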

Compound 4, a percentage reported as inhibition, at one concentration (the size of the read-out at that concentration, not a potency): 67%
Compound 4: the middle estimate sits 22 percentage points below what was measured; measured number inside the range.
By their numbers in this assay, from the lowest: compound 3; then compounds 2 and 4 (each within the scatter of the next); then compound 1.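

In this assay, among the compounds shown here, the earlier compounds all carried halogen on the aryl group at the sulfonyl sulfur, and the new result shows that halogen is not needed there for a high number: the 4-methoxyphenyl group, which has no halogen, gives a step of a number 58 percentage points higher from compound 3 to compound 4 (beyond the scatter). This group cannot be told apart from 3-fluorophenyl, with a step of a number 5 percentage points higher from compound 2 to compound 4 (within the scatter), but it does not reach 3,5-dichlorophenyl, with a step of a number 15 percentage points lower from compound 1 to compound 4 (beyond the scatter), so compound 1 keeps the highest number of the four and compound 3 stands alone at the low end. No measurement is available that explains why these groups on the sulfonyl sulfur differ as they do.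

The compounds shown leave open what a plain phenyl group on the sulfonyl sulfur would give, and whether an amine or a carboxylic acid in place of the methoxy group would keep the inhibition. The rest of the shared core is the same in all four compounds, so they also do not tell what an ethyl group in place of its methyl group would do.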